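A few compounds are considered here, and "the series" means these few. Any claim that something is new, unique, unknown or untested is made for them only; others in the source may bear on it.

Of the compounds shown here, three of one series have been measured in a functional assay on HeLa cells (Homo sapiens) for cytotoxicity, read by WST assay, with a stated time of 48 h; a higher number here means a weaker inhibitor, a lower number a stronger inhibitor. Compound 1 `COc1cccc([C@H](O)[C@H]2CO[C@H](c3ccc(OC)c(OC)c3)[C@@H](C/C=C/c3ccc(OC)c(OC)c3)C2)c1` gives 21200 nM in this assay, and compound 3 `COc1cccc([C@H]2OC[C@H]([C@@H](O)c3ccc(OC)c(OC)c3)C[C@@H]2C/C=C/c2ccc(OC)c(OC)c2)c1` gives 21800 nM; these two values lie within the usual scatter of each other. Compound 2 `O[C@@H](c1ccccc1)[C@H]1CO[C@H](c2ccccc2)[C@@H](C/C=C/c2ccncc2)C1` gives > 100000 nM, which is a limit of the assay and not a number. On the numbers shown, compound 2 therefore stands at the limit of > 100000 nM in this assay, at which 1 of the 3 values shown sits. Among the compounds with values here, no two measured compounds differ in a single place, so no measured step is available. Compound 4 `Oc1ccc(/C=C/C[C@H]2C[C@@H]([C@@H](O)c3ccccc3)CO[C@@H]2c2ccccc2)cc1` has not yet been measured. Its change from compound 2 is 4-hydroxyphenyl in place of pyridin-4-yl on a double-bonded chain carbon bound to a double-bonded chain carbon. Without a measured step to lean on, the size of this step in this assay is uncertain; a move toward a stronger inhibitor seems possible, but a step beyond the scatter is not assured, and compound 4 may again sit at the limit. Compound 4 is estimated at 80000 nM, with a range from 25000 nM to 250000 nM. The expected step from compound 2 to compound 4 is an at least 1.2-fold lower number from compound 2 to compound 4 (0.09 log units; that floor lies within the scatter).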

Compound 4, half-maximal inhibitory concentration: 14400 nM
Compound 4: middle estimate off by 5.6-fold (0.74 log units), on the high side; measured number outside the range, below it.
By their numbers in this assay, from the lowest: compounds 4, 1 and 3 (each within the scatter of the next). At a limit, above all of these: compound 2.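

In this assay, 4-hydroxyphenyl in place of pyridin-4-yl on a double-bonded chain carbon bound to a double-bonded chain carbon gives an at least 6.9-fold lower number from compound 2 to compound 4 (0.84 log units; beyond the scatter). Within the data shown here, this is the first single-place step measured, and it shows that changing the aromatic ring at the end of this chain, with the rest of the structure held constant, can move the number beyond the scatter. Compound 2 stands at a limit of the assay and not at a number: the limit of > 100000 nM in this assay, at which 1 of the 4 values shown sits.

This one change removes the ring nitrogen and adds the hydroxyl together, and the compounds shown cannot tell which of the two matters. Also open, as far as these compounds go, is what a 4-aminophenyl, with an amine where compound 4 carries its hydroxyl, would give at this place.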